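This account rests on a few compounds, and the source may have more. Where it says the series, first, only, none or still open, it means among the compounds named here.

In a functional assay on EBC-1 cells (Homo sapiens) for antiproliferative activity, with a stated time of 72 h (a lower number here means a stronger inhibitor, a higher number a weaker inhibitor), three compounds sharing one core have been measured. Compound 1 `Fc1cc(-c2ccsc2)cn2c(Cc3ccc4ncccc4c3)cnc12` gives 444 nM, compound 2 `N#Cc1cccc(-c2cc(F)c3ncc(Cc4ccc5ncccc5c4)n3c2)c1` gives 107 nM, and compound 3 `Fc1cc(F)cc(-c2cc(F)c3ncc(Cc4ccc5ncccc5c4)n3c2)c1` gives 790 nM. Compound 3 cannot be told apart from compound 1, since a 1.8-fold higher number from compound 1 to compound 3 (0.25 log units; within the scatter) stays within the scatter, whereas a 7.4-fold higher number from compound 2 to compound 3 (0.87 log units; beyond the scatter) is a clear gap. Compound 4 `N#Cc1ccc(-c2cc(F)c3ncc(Cc4ccc5ncccc5c4)n3c2)cc1F` changes one group of compound 3: 4-cyano-3-fluorophenyl in place of 3,5-difluorophenyl on an aromatic carbon. In words, 4-cyano-3-fluorophenyl replaces 3,5-difluorophenyl on an aromatic carbon. Among the measured compounds shown here, the nearest guide is compound 2, the only measured compound with a nitrile, which also has the lowest number, with a 4.1-fold lower number from compound 1 to compound 2 (0.62 log units; beyond the scatter) on the way to it. For the measured compounds named here, no measured compound carries the entering group itself, and the evidence for a nitrile rests on compound 2 alone, so only part of that gap is expected to carry over. A modest move to a lower number is therefore expected, an estimated 3.6-fold lower number from compound 3 to compound 4 (0.56 log units; beyond the scatter). For compound 4 the estimate is 220 nM, with an expected range of 70 nM to 650 nM.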

Compound 4, half-maximal inhibitory concentration: 145 nM
Compound 4: middle estimate off by 1.5-fold (0.18 log units), on the high side, within the range that was stated.
By their numbers in this assay, from the lowest: compounds 2 and 4 (each within the scatter of the next); then compounds 1 and 3 (each within the scatter of the next).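

In this assay this position responds to a second nitrile-bearing aryl group as well, with a 5.4-fold lower number from compound 3 to compound 4 (0.74 log units; beyond the scatter) and a 3.1-fold lower number from compound 1 to compound 4 (0.49 log units; beyond the scatter), so the link between a nitrile and a lower number no longer rests on compound 2 alone; among these four compounds, none goes against it. The two nitrile-bearing groups cannot be told apart, with a 1.4-fold higher number from compound 2 to compound 4 (0.13 log units; within the scatter), so moving the nitrile on the phenyl ring and adding a fluoro group together leave the number within the scatter. Nothing shown here explains these steps.

The compounds shown leave open whether a primary amide or a methoxy group could stand in for the nitrile, and what the fluoro group of 4-cyano-3-fluorophenyl adds on its own. They also leave open how an amine or a carboxylic acid on this phenyl ring would behave.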